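The source may report more compounds than this note shows. Statements on the series, on what has been measured and on what is new or still open speak of the compounds shown alone.

Among the compounds with values here, compound 2 `CCC(C)(C)Cc1c[nH]c(CCc2ccc(-c3ccc(F)cn3)cc2)n1` stands at the low end of the three numbers measured so far: in an in vitro assay on CHO cells for displacement of a labelled ligand from Bombesin receptor subtype-3 (Homo sapiens), read by scintillation counting, with a stated time of 2 h (on this read-out lower numbers stand for stronger inhibition and higher numbers for weaker inhibition), compound 2 gives 19 nM, while compound 1 `CCC(C)(C)Cc1c[nH]c(CCc2ccc(-n3ncnn3)cc2)n1` gives 205 nM and compound 3 `c1ccc(-c2ccc(CCc3nc(CC4CCCC4)c[nH]3)cc2)nc1` gives 177 nM. Compound 3 differs from compound 2 in two places at once, so its value shows only that it sits well above compound 2. Within the data shown here, compound 1 differs in one place, and that single step, an 11-fold lower number from compound 1 to compound 2 (1.03 log units; beyond the scatter), is the only measured step that bears on the change now in question.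

Compound 4 `CCC(C)(C)Cc1c[nH]c(CCc2ccc(-c3ccns3)cc2)n1` is compound 2 with 1,2-thiazol-5-yl in place of 5-fluoropyridin-2-yl on an aromatic carbon. Among the measured compounds shown here, the one comparable step shows that on this same aromatic carbon a five-membered ring with several hetero atoms was matched with a much higher number than the six-membered fluorinated ring, though the new five-membered ring is not the same as the one in compound 1.

On that basis the expectation for compound 4 is a moderately higher number than compound 2, a 3.2-fold higher number from compound 2 to compound 4 (0.50 log units; beyond the scatter), because of what an 11-fold lower number from compound 1 to compound 2 (1.03 log units; beyond the scatter) showed for the earlier five-membered ring, with a good deal of uncertainty. Compound 4 is therefore estimated at 60 nM, within a range of 20 nM to 180 nM.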

Compound 4, half-maximal inhibitory concentration: 11 nM
Compound 4: the middle estimate sits 5.5-fold (0.74 log units) above what was measured; the whole stated range lies above it.
By their numbers in this assay, from the lowest: compounds 4 and 2 (each within the scatter of the next); then compounds 3 and 1 (each within the scatter of the next).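

In this assay, the exchange on this aromatic carbon, para to a large group, gives a 1.7-fold lower number from compound 2 to compound 4 (0.24 log units; within the scatter), so 1,2-thiazol-5-yl and 5-fluoropyridin-2-yl cannot be told apart here, even though one is a five-membered aromatic ring and the other a six-membered one. The earlier step set only 2H-tetrazol-2-yl against a six-membered ring, whereas a 19-fold lower number from compound 1 to compound 4 (1.27 log units; beyond the scatter) now separates two five-membered rings at the same place, so ring size alone does not follow the numbers across these compounds, with compound 4 going against the link that compound 1 alone had suggested. Nothing among the available data accounts for the distance between these two five-membered rings.

The compounds shown leave open how this position would respond to a group of another kind, such as a carboxylic acid or a dimethylamino group, in place of these aromatic rings. They also leave open whether 1,2-thiazol-5-yl would give a comparable number when combined with the side chain carried by compound 3, since the shared core has so far been paired with it only in the form seen in compound 4.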